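Half-life of an Acyloxymethyl Carbamate with Bromo for Cyano

A few compounds are considered here, and "the series" means these few. Any claim that something is new, unique, unknown or untested is made for them only; others in the source may bear on it.

Compound 1 `Cc1ncc([N+](=O)[O-])n1CCOC(=O)CCCC(=O)OCCn1c([N+](=O)[O-])cnc1C`: 0.61 h
Compound 2 `NCCCC[C@H](N)C(=O)OC[C@H]1O[C@@H](n2cc(F)c(=O)[nH]c2=O)C[C@@H]1O`: 0.647 h
Compound 3 `CC(=O)OCOC(=O)N(C)/N=N/c1ccc(C#N)cc1`: 0.117 h

In an ADME assay on a cell-free system (plasma, Homo sapiens) for metabolic stability (a higher number here means that the compound lasts longer, a lower number that the compound disappears faster), compound 3 gives the lowest of the three numbers; compound 1 and compound 2 both sit well above it, by margins beyond the scatter. Compound 4 `CC(=O)OCOC(=O)N(C)/N=N/c1ccc(Br)cc1` carries the same acetoxymethyl carbamate and triazene portion as compound 3, with one change: bromo in place of cyano on an aromatic carbon. Within the data shown here, no measured pair in this set shows what such a swap does to the half-life. Since the ester and carbamate parts that compound 3 and compound 4 share are untouched, the step of a 1.1-fold higher number from compound 3 to compound 4 (0.05 log units; within the scatter) is expected to stay within the scatter, with no clear direction. Compound 4 is therefore estimated at 0.13 h, in a range from 0.06 h to 0.28 h.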

Compound 4, half-life: 0.283 h
Beside the measured number, compound 4's estimate is 2.2-fold (0.34 log units) below it; measured number above the stated range.
By their numbers in this assay, from the lowest: compound 3; then compound 4; then compounds 1 and 2 (each within the scatter of the next).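

Bromo in place of cyano on an aromatic carbon, para to a large group, gives a 2.4-fold higher number from compound 3 to compound 4 (0.38 log units; beyond the scatter) in this assay while the acetoxymethyl carbamate stays unchanged. Among these compounds, this is the first matched pair here, and it shows that the group at this aromatic position alone can shift the half-life beyond the scatter. No available evidence accounts for the step. The compounds shown leave open how methoxy or chloro at this position would compare with bromo and cyano. They also leave open whether the same swap would shift the half-life in a carbamate carrying a longer acyl chain.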